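Capping an Aromatic Amine With a Tosyl Group

The source may report more compounds than this note shows. Statements on the series, on what has been measured and on what is new or still open speak of the compounds shown alone.

Of the compounds shown here, two sharing one core have been measured in a functional assay on A549 cells (Homo sapiens) for inhibition, read by sulforhodamine B assay; on this read-out lower numbers stand for stronger inhibition of growth and higher numbers for weaker inhibition of growth. Compound 1 `Nc1ccc(CNC(=O)CC2c3ccccc3N=C(N3CCCCC3)N2c2ccccc2)cc1` gives 36600 nM in this assay, the lower of the two numbers. Compound 2 `CCN1C(N2CCCCC2)=Nc2ccccc2C1CC(=O)NCc1ccccc1` gives 95100 nM in this assay, a number that stands beyond the usual scatter above that of compound 1. Among the compounds with values here, these two differ in more than one place, so their numbers show only that compound 1 is the more potent of the pair.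

Compound 3 `Cc1ccc(S(=O)(=O)Nc2ccc(CNC(=O)CC3c4ccccc4N=C(N4CCCCC4)N3c3ccccc3)cc2)cc1` has not been measured. Relative to compound 1, its change is (4-methylphenyl)sulfonyl in place of hydrogen on a nitrogen on an aromatic ring. Within the data shown here, no pair of measured compounds differs only in this way, so the size of this step is an expectation rather than an observation. The change is expected to move the number only modestly, toward slightly stronger inhibition of growth, with a step estimated at a 1.8-fold lower number from compound 1 to compound 3 (0.26 log units; within the scatter). Compound 3 is therefore expected to give about 20000 nM in this assay, with a likely range from 5000 nM to 80000 nM.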

Compound 3, concentration for 50% growth inhibition: 3060 nM
Compound 3: the middle estimate sits 6.5-fold (0.82 log units) above what was measured; measured number below the stated range.
By their numbers in this assay, from the lowest: compound 3; then compound 1; then compound 2.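

Within the data shown here, putting (4-methylphenyl)sulfonyl in place of hydrogen on a nitrogen on an aromatic ring gives a 12-fold lower number from compound 1 to compound 3 (1.08 log units; beyond the scatter) in this assay and this is the first single change whose size can be read on its own. It shows that this nitrogen is a place where the number responds strongly, and that adding a group of 10 heavy atoms, with one more aromatic ring, goes with stronger inhibition of growth rather than weaker. No measurement shown here bears on why the number falls.

Among these compounds, with only one sulfonyl compound in view, it remains open which part of the added group goes with the step: the methyl on the ring, the ring itself, or the sulfonyl link, and a smaller methanesulfonyl or an acetyl on the same nitrogen would begin to separate these. Also open, on these data alone, is whether a step of this size would hold with the ethyl of compound 2 in place of the phenyl of compound 1, since the tosyl group has been seen on only one background.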